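The compounds below may be only part of what the source reports. "The series", "measured", "known", "first", "only" and "open" are said of these compounds alone.

Of the compounds shown here, three have so far been measured in a functional assay on HL-60 cells (Homo sapiens) for antiproliferative activity, read by sulforhodamine B assay, with a stated time of 72 h; on this read-out lower numbers stand for stronger inhibition and higher numbers for weaker inhibition. Compound 1 `O=C1CS/C(=N/Nc2nncc3ccccc23)N1c1ccccc1` gives 3 nM, and compound 3 `C(=C/c1ccccc1)\C(=N\Nc1nncc2ccccc12)c1ccccc1` gives 4.7 nM; these two numbers lie within the scatter of one another, so no order between them can be claimed. Compound 2 `O=S(=O)(Nc1ccccn1)c1ccc(Nc2nncc3ccccc23)cc1` gives 86 nM, the highest of the three numbers. Its gap to compound 3 is beyond the scatter, and its gap to compound 1 is wider still, so on this read-out compound 2 stands as the weakest inhibitor of the three.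

Compound 4 `O=S(=O)(Nc1nccs1)c1ccc(Nc2nncc3ccccc23)cc1` has not yet been measured. It differs from compound 2 in one place: 1,3-thiazol-2-yl in place of pyridin-2-yl on a sulfonamide nitrogen. Everything else in the two structures is the same. Going by the values given here, no measured pair in this set shows the effect of such a change on a sulfonamide nitrogen, so there is no directly comparable step to lean on. The change is limited in size, one five-membered aromatic ring with two hetero atoms entering where a six-membered aromatic ring with one hetero atom leaves, and the step of a 1.2-fold lower number from compound 2 to compound 4 (0.09 log units; within the scatter) is expected to be modest, most likely within the scatter or only slightly toward a lower number. The estimate for compound 4 in this assay is 70 nM, with a range from 25 nM to 250 nM.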

Compound 4, half-maximal inhibitory concentration: 77 nM
The estimate for compound 4 lay 1.1-fold (0.04 log units) below the measured number, and the stated range covers the measured number.
By their numbers in this assay, from the lowest: compounds 1 and 3 (each within the scatter of the next); then compounds 4 and 2 (each within the scatter of the next).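

Going by these compounds alone, the step, a 1.1-fold lower number from compound 2 to compound 4 (0.05 log units; within the scatter), gives the first reading of this position in this assay: on a sulfonamide nitrogen whose other neighbour is the sulfonyl sulfur, 1,3-thiazol-2-yl in place of pyridin-2-yl makes no difference that can be told from the usual scatter. One five-membered aromatic ring with 2 hetero atoms can therefore stand where a six-membered aromatic ring with 1 hetero atom stood, and this single pair shows no loss or gain on this read-out. No measured property in hand bears on this result.

The two groups shown on this nitrogen are both aromatic rings, so it remains open whether the number would hold with a simple methyl group, a plain phenyl ring, or a chain ending in an amine or a carboxylic acid. Compound 1 and compound 3 differ from this pair in more than one place, so the step says nothing about which part of the structures separates their numbers from those of compound 2 and compound 4.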